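Replacing the aryl group of compound 3

This account rests on a few compounds, and the source may have more. Where it says the series, first, only, none or still open, it means among the compounds named here.

Values in a functional assay on PANC-1 cells (Homo sapiens), read by microscopy, crystal violet staining and transwell migration, with a stated time of 18 h, in the presence of a further agent that is not named here; a higher number here means a weaker inhibitor, a lower number a stronger inhibitor:
- compound 1 `CCOc1ccc(-c2nc(CC)nn2-c2cccc(C(=O)NCCCCc3ccccc3)c2)cc1`: 16800 nM
- compound 2 `CCc1nc(-c2ccc(OC(F)F)cc2)n(-c2cccc(C(=O)NCCCCc3ccccc3)c2)n1`: 830 nM
- compound 3 `CCc1nc(-c2ccc(OC(F)(F)F)cc2)n(-c2cccc(C(=O)NCCCCc3ccccc3)c2)n1`: 640 nM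

Compound 3 stands at the low end of these numbers, level with its nearest neighbour: a 1.3-fold lower number from compound 2 to compound 3 (0.11 log units; within the scatter). Compound 4 `CCc1nc(-c2ccc(OC)nc2)n(-c2cccc(C(=O)NCCCCc3ccccc3)c2)n1` carries 6-methoxypyridin-3-yl in place of 4-(trifluoromethoxy)phenyl on an aromatic carbon. Among the compounds with values here, no measured step changes the ring itself, so what that does is unknown. The closest evidence concerns the group on oxygen, with two large steps: a 20-fold lower number from compound 1 to compound 2 (1.31 log units; beyond the scatter) and a 26-fold lower number from compound 1 to compound 3 (1.42 log units; beyond the scatter). Compound 4 has no fluorine in that group, like compound 1 at 16800 nM, so a large step back towards that number is expected. The expected step is a 6.3-fold higher number from compound 3 to compound 4 (0.80 log units; beyond the scatter). For compound 4 the estimated value is 4000 nM, with an expected range from 900 nM to 18000 nM.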

Compound 4, half-maximal inhibitory concentration: 810 nM
Compound 4: the middle estimate sits 4.9-fold (0.69 log units) above what was measured; the whole stated range lies above it.
By their numbers in this assay, from the lowest: compounds 3, 4 and 2 (each within the scatter of the next); then compound 1.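

Fluorine on the oxygen group is not needed for a low number at this position: 6-methoxypyridin-3-yl has none, yet a 1.3-fold higher number from compound 3 to compound 4 (0.10 log units; within the scatter) and a 1.0-fold lower number from compound 2 to compound 4 (0.01 log units; within the scatter) leave it level with both fluorinated groups in this assay on this core. The large step is a 21-fold lower number from compound 1 to compound 4 (1.32 log units; beyond the scatter) against 4-ethoxyphenyl, so these two fluorine-free groups lie far apart. Nothing measured here explains this difference.

Whether the ring nitrogen or methoxy in place of ethoxy accounts for that gap stays open, since both change together. 4-Methoxyphenyl or 6-ethoxypyridin-3-yl, each changing only one of the two, would separate them.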